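Notes on the hydrazone aryl swap in the shared core

The compounds below may be only part of what the source reports. "The series", "measured", "known", "first", "only" and "open" are said of these compounds alone.

Measured compounds:
compound 1 `CCCSc1nc(N/N=C/c2ccc(N(C)C)cc2)c2nnn(Cc3ccccc3)c2n1`: 12200 nM
compound 2 `C#CCSc1nc(N/N=C/c2ccc(N(C)C)cc2)c2nnn(Cc3ccccc3)c2n1`: a limit, > 64000 nM
compound 3 `C#CCSc1nc(N/N=C/c2cc(OC)c(OC)c(OC)c2)c2nnn(Cc3ccccc3)c2n1`: 17000 nM

In a functional assay on MCF7 cells (Homo sapiens) for antiproliferative activity, read by MTT assay, with a stated time of 72 h (on this read-out higher numbers stand for weaker inhibition and lower numbers for stronger inhibition), compound 1 gives the lowest of the two numbers, and compound 3 sits within the scatter of it. Compound 2 reaches only a limit of the assay, (the limit of > 64000 nM in this assay, at which 1 of the 3 values shown sits). Among the compounds with values here, the single measured step, an at least 5.2-fold higher number from compound 1 to compound 2 (0.71 log units; beyond the scatter), sits on the chain at the sulfur and does not touch the hydrazone aryl. Compound 4 `CCCSc1nc(N/N=C/c2c(O)ccc3ccccc23)c2nnn(Cc3ccccc3)c2n1` differs from compound 1 by 2-hydroxynaphthalen-1-yl in place of 4-(dimethylamino)phenyl on a carbon with a double bond to nitrogen. Within the data shown here, no measured step bears on this change; compounds 1 and 3 differ at the same aryl but also at the sulfur chain. For compound 4 a step of a 1.0-fold lower number from compound 1 to compound 4 (0.01 log units; within the scatter) is expected, none beyond the scatter. Compound 4 is estimated at 12000 nM, between 4000 nM and 40000 nM.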

Compound 4, half-maximal inhibitory concentration: 6400 nM
Estimate against measurement, compound 4: 1.9-fold (0.27 log units) above, and the stated range covers the measured number.
By their numbers in this assay, from the lowest: compounds 4, 1 and 3 (each within the scatter of the next, the first and the last beyond it). At a limit, above all of these: compound 2.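

In this assay, within the data shown here, the first step confined to the hydrazone aryl gives a 1.9-fold lower number from compound 1 to compound 4 (0.28 log units; within the scatter), so this position takes 2-hydroxynaphthalen-1-yl in place of 4-(dimethylamino)phenyl without a difference beyond the scatter. The swap brings a second six-membered aromatic ring and a hydrogen-bond donor and removes the nitrogen of the leaving group, yet the read-out stays within the scatter. Nothing shown accounts for this result.

Open, on these data alone, is whether 2-hydroxynaphthalen-1-yl gives a similar reading with the ethynyl-bearing chain on sulfur. Also open, as far as these compounds go, is whether a carboxylic acid on the hydrazone aryl, or a longer chain on sulfur, would move the number beyond the scatter.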